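This account rests on a few compounds, and the source may have more. Where it says the series, first, only, none or still open, it means among the compounds named here.

Compound 2, with the structure `O=C(/N=C(/NC(=O)c1ccco1)[Se]Cc1ccccc1)c1ccco1`, and compound 1, with the structure `C[Se]/C(=N\C(=O)c1ccco1)NC(=O)c1ccco1`, share one core and differ only at the selenium: hydrogen in place of phenyl on a saturated chain carbon bound to a selenium atom. In a functional assay on PC-3 cells (Homo sapiens) for cytotoxicity, read by MTT assay, with a stated time of 72 h (on this read-out higher numbers stand for weaker inhibition of growth and lower numbers for stronger inhibition of growth), compound 2 gives 57600 nM, and compound 1 gives 56700 nM. The step between them, a 1.0-fold lower number from compound 2 to compound 1 (0.01 log units; within the scatter), shows that trimming the group on the saturated chain carbon bound to the selenium atom left the outcome essentially unchanged.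

Compound 3, with the structure `O=C(/N=C(/NC(=O)c1csc([N+](=O)[O-])c1)[Se]Cc1ccccc1)c1csc([N+](=O)[O-])c1`, carries a different core from compound 2; how the two cores differ is not broken down here. In this assay compound 3 gives 69200 nM, a number that sits within the scatter of compound 2 and of compound 1 alike, so nothing can be said about an order among these three.

Compound 4, with the structure `C[Se]/C(=N\C(=O)c1csc([N+](=O)[O-])c1)NC(=O)c1csc([N+](=O)[O-])c1`, is to compound 3 what compound 1 is to compound 2: hydrogen in place of phenyl on a saturated chain carbon bound to a selenium atom. Within the data shown here, the change is the same kind of change as the one from compound 2 to compound 1, made at the same place and against a different core. Only one earlier example of this change exists among these compounds, and it is within the scatter; there is no sign that the core alters the reading of this change, but also no second example to confirm it. The expected step from compound 3 to compound 4 in this assay is therefore a 1.0-fold lower number from compound 3 to compound 4 (0.01 log units; within the scatter), resting on a 1.0-fold lower number from compound 2 to compound 1 (0.01 log units; within the scatter). For compound 4 the estimated value in this assay is 68000 nM, with a range from 38000 nM to 125000 nM.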

Compound 4, concentration for total growth inhibition: 7090 nM
Beside the measured number, compound 4's estimate is 9.6-fold (0.98 log units) above it; the whole stated range lies above it.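

In this assay, replacing benzyl with methyl, on the saturated chain carbon bound to a selenium atom, gives a 9.8-fold lower number from compound 3 to compound 4 (0.99 log units; beyond the scatter), whereas the same change on the core of compound 2 gave a 1.0-fold lower number from compound 2 to compound 1 (0.01 log units; within the scatter). Among these compounds, a lower number here means stronger inhibition of growth, so the change strengthens inhibition on the core of compound 3 but leaves it essentially unchanged on the core of compound 2, and its effect on one core could not simply be carried over to the other: the same change on two cores in this assay, a 1.0-fold lower number (0.01 log units; within the scatter) from compound 2 to compound 1 and a 9.8-fold lower number (0.99 log units; beyond the scatter) from compound 3 to compound 4, 9.6-fold (0.98 log units) apart, beyond the scatter of two such steps This comparison rests on only one pair of compounds per core, so it shows that the outcome of this change depends on the core in these two cases, but not which part of the difference between the cores is responsible or how the change would behave on a third core.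

On these data alone, only benzyl and methyl appear at this place, so it remains open whether a longer chain such as ethyl or propyl, or a chain ending in an amine, would behave more like the methyl of compound 4 or the benzyl of compound 3 on this core. As far as these compounds go, it also remains open whether the same difference between the two cores would appear in any other assay.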